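The source may hold more compounds than are shown below. What is called first, only, known or untested is meant among the compounds shown, and "the series" means these compounds.

Of the compounds shown here, three have so far been tested in a functional assay on PC-3 cells (Homo sapiens) for inhibition, read by MTT assay, with a stated time of 24 h (on this read-out higher numbers stand for weaker inhibition and lower numbers for stronger inhibition), and none gave an exact number. Compound 1 (`CCOC1c2cc(OCc3cc(C)cc(C)c3)c(OCc3cc(C)cc(C)c3)cc2CCN1C(=O)OC(C)(C)C`) gives > 20000 nM as a limit of the assay. Compound 2 (`C/C=C/C(=O)CC1c2cc(OCc3cc(C)cc(C)c3)c(OCc3cc(C)cc(C)c3)cc2CCN1C(=O)OC(C)(C)C`) gives > 20000 nM as a limit too. Compound 3 (`CC[C@@H]1CC(=O)C/C=C(/C)[C@H]2c3cc(OCc4ccccc4)c(OCc4ccccc4)cc3CCN12`) gives > 20000 nM as a limit as well. Compound 2 therefore has no exact place on the scale, and all three results share one limit (the limit of > 20000 nM in this assay, at which 3 of the 3 values shown sit).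

Compound 4 (`Cc1cc(C)cc(COc2cc3c(cc2OCc2cc(C)cc(C)c2)CN(C(=O)OC(C)(C)C)CC3)c1`) is compound 2 with hydrogen in place of ((prop-1-en-1-yl)carbonyl)methyl on a saturated ring carbon. Within the data shown here, the one measured change at such a carbon is a step that the two limits leave unreadable from compound 1 to compound 2 so no step beyond the scatter is expected for compound 4. The estimated step (a number no higher from compound 2 to compound 4 (the limit leaves the size open)) carries no firm direction. For compound 4 the estimate is 20000 nM with an expected range from 9000 nM to 40000 nM and a result given only as a limit is the likeliest outcome.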

Compound 4, half-maximal inhibitory concentration: > 20000 nM
Compound 4: a limit, no number; the forecaster's own chance of this, stated with the estimate: 75%; the middle value sits exactly at the limit.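

Compound 4, like compound 1 and compound 2, gives only a limit and no exact number, so the steps between these three cannot be read: the limit of > 20000 nM in this assay, at which 4 of the 4 values shown sit.

The compounds shown leave open whether the group on the saturated ring carbon affects inhibition in this assay at all.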